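The source may report more compounds than this note shows. Statements on the series, on what has been measured and on what is new or still open speak of the compounds shown alone.

In a functional assay on SW480 cells (Homo sapiens) for inhibition (a lower number here means a stronger inhibitor, a higher number a weaker inhibitor), compound 1 (`COc1cc[nH]c1/C=C1\C(=O)Nc2ccc(F)c(C#C[C@@H](C)O)c21`) gives 130 nM while compound 2 (`COc1cc[nH]c1/C=C1\C(=O)Nc2ccc(F)c(C#C[C@@H](N)CO)c21`) gives 205 nM and compound 3 (`COc1cc[nH]c1/C=C1\C(=O)Nc2ccc(F)c(C#CC3(O)CCOCC3)c21`) gives 290 nM on the same shared core. Compound 3 stands apart from only one of the other two: one step (a 2.2-fold higher number from compound 1 to compound 3 (0.35 log units; beyond the scatter)) separates it, the other (a 1.4-fold higher number from compound 2 to compound 3 (0.15 log units; within the scatter)) does not. Compound 4 (`COc1cc[nH]c1/C=C1\C(=O)Nc2ccc(F)c(C#C[C@@H]3C[C@H](O)CN3)c21`) differs from compound 3 by one change (4-hydroxypyrrolidin-2-yl in place of 4-hydroxyoxan-4-yl on a triple-bonded carbon) on a triple-bonded carbon, where 4-hydroxypyrrolidin-2-yl comes in place of 4-hydroxyoxan-4-yl. Within the data shown here, no measured step makes this exchange. The closest guide is compound 2 at 205 nM whose 1-amino-2-hydroxyethyl group also holds both nitrogen and oxygen. Exchanges at this place have so far stayed small, with the step to that group (a 1.6-fold higher number from compound 1 to compound 2 (0.20 log units; within the scatter)) and the largest one being only modest. The expected step (a 1.5-fold lower number from compound 3 to compound 4 (0.16 log units; within the scatter)) is slightly downward, and nothing beyond the scatter is expected in this assay here. Compound 4 is estimated at 200 nM (expected range 90 nM to 450 nM).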

Compound 4, half-maximal inhibitory concentration: 90 nM
The estimate for compound 4 lay 2.2-fold (0.35 log units) above the measured number, within the range that was stated.
By their numbers in this assay, from the lowest: compounds 4, 1, 2 and 3 (each within the scatter of the next, the first and the last beyond it).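

In this assay, 4-hydroxypyrrolidin-2-yl in place of 4-hydroxyoxan-4-yl on a triple-bonded carbon gives a 3.2-fold lower number from compound 3 to compound 4 (0.51 log units; beyond the scatter), and in place of 1-amino-2-hydroxyethyl it gives a 2.3-fold lower number from compound 2 to compound 4 (0.36 log units; beyond the scatter), so holding both nitrogen and oxygen does not by itself settle the number at this place. Set against the small 1-hydroxyethyl group, the same ring gives a 1.4-fold lower number from compound 1 to compound 4 (0.16 log units; within the scatter), which leaves compound 4 and compound 1 indistinguishable here, so two quite different groups can serve equally well at this place. Nothing available here accounts for these steps.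

The compounds shown leave open whether the ring nitrogen or the hydroxyl of 4-hydroxypyrrolidin-2-yl carries the step, and how far its two defined stereocentres matter. They also do not tell how an unsubstituted pyrrolidin-2-yl, a piperidine ring or a carboxylic acid would behave on this triple-bonded carbon.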